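The compounds below may be only part of what the source reports. "The series", "measured", "known", "first", "only" and "open" are said of these compounds alone.

Measured compounds:
Compound 1, `O=C1c2ccccc2NS(=O)(=O)N1COCCO`: in a functional assay on CCRF-CEM cells (Homo sapiens) for cytotoxicity (a higher number here means that more compound is tolerated, a lower number that less compound is tolerated), compound 1 gives > 200 ug/mL, a limit of the assay rather than a number.
Compound 2, `O=C1c2ccccc2N(COCc2ccccc2)S(=O)(=O)N1Cc1ccccc1`: in this assay compound 2 gives 25 ug/mL.
Compound 3, `CCCOCN1c2ccccc2C(=O)NS1(=O)=O`: in this assay compound 3 gives > 200 ug/mL, again a limit and not a number.

Within the data shown here, compound 2 therefore stands as the only measured number in the set; the other two results are limits. Two of the three results sit at the limit of > 200 ug/mL in this assay, at which 2 of the 3 values shown sit.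

Compound 4, `O=C1c2ccccc2NS(=O)(=O)N1Cc1ccccc1`, is not yet measured in this assay. It differs from compound 2 in one place: hydrogen in place of (benzyloxy)methyl on a sulfonamide nitrogen in a ring. Among the measured compounds shown here, no measured step of this kind exists among the three compounds, so the expectation rests on the structures alone. Compound 4, like compound 1 and compound 3, carries hydrogen on a sulfonamide nitrogen, and the estimate leans toward tolerance of more compound due to the limit of > 200 ug/mL in this assay, at which 2 of the 3 values shown sit. Compound 4 is estimated at 120 ug/mL, with a range from 40 ug/mL to 250 ug/mL. The expected step is a 4.8-fold higher number from compound 2 to compound 4 (0.68 log units; beyond the scatter), beyond the scatter, and a limit rather than a number is considered quite possible.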

Compound 4, half-maximal cytotoxic concentration: > 200 ug/mL
Compound 4 gave a limit, no number; the forecaster's own chance of this, stated with the estimate: 50%; middle value at least 1.6-fold (0.22 log units) away from the limit.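

Among these compounds, this is the first readable step at this position: in this assay, hydrogen in place of (benzyloxy)methyl on the sulfonamide nitrogen in the ring gives an at least 8.0-fold higher number from compound 2 to compound 4 (0.90 log units; beyond the scatter). With the benzyl group kept in both compounds, the cytotoxicity that compound 2 shows as a number depends on the (benzyloxy)methyl, and the benzyl group alone does not bring compound 4 to a number. The size of the step is only a lower bound, because compound 4 gives a limit and not a number: the limit of > 200 ug/mL in this assay, at which 3 of the 4 values shown sit.

The step from compound 1 to compound 4 cannot be read, with both results being limits. Still open, from the compounds shown here alone, is whether the change belongs to the aromatic ring of the (benzyloxy)methyl or to the group as a whole, which a methyl or methoxymethyl group on this nitrogen, with the benzyl group kept, would separate.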